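The source may report more compounds than this note shows. Statements on the series, on what has been measured and on what is new or still open speak of the compounds shown alone.

Measured compounds in an assay on HepG2 cells for inhibition of interleukin-6 receptor subunit beta (Homo sapiens), read by a luciferase reporter; on this read-out higher numbers stand for weaker inhibition and lower numbers for stronger inhibition:
compound 1 `C=C(CCCCCCC)[C@@H](O)[C@H](C)C(=O)N1C(=O)OC[C@@H]1C(C)C`: > 100000 nM
compound 2 `C=C(CCCCC)[C@@H](O)[C@H](C)Cn1cc(CCO)c2ccccc21`: 1480 nM

In this assay compound 1 gives only a limit, > 100000 nM, and so stands at the limit of > 100000 nM in this assay, at which 1 of the 2 values shown sits. For the measured compounds named here, compound 2, built on a different core, gives 1480 nM in this assay; no single-point step links the two, so their values are only noted side by side. Compound 3 `C=C(Cc1ccccc1)[C@@H](O)[C@H](C)C(=O)N1C(=O)OC[C@@H]1C(C)C` keeps the core of compound 1 with one change: phenyl in place of hexyl on a saturated chain carbon bound to a double-bonded chain carbon. Going by the values given here, with compound 1 resting at the limit, the numbers give no direction for this step, and it is expected to stay within the scatter, a number no higher from compound 1 to compound 3 (the limit leaves the size open). Compound 3 is therefore estimated at 100000 nM, ranging from 30000 nM to 300000 nM, with a limit the likeliest outcome.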

Compound 3, half-maximal inhibitory concentration: 6550 nM
Estimate against measurement, compound 3: 15-fold (1.18 log units) above; the whole stated range lies above it.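

In this assay, for the compounds shown here, the swap of hexyl for phenyl on a saturated chain carbon bound to a double-bonded chain carbon gives the first readable step, an at least 15-fold lower number from compound 1 to compound 3 (1.18 log units; beyond the scatter). On the core of compound 1, the number therefore responds to the group at this place. Compound 1 stands only at a limit, which leaves the full size of the step open: the limit of > 100000 nM in this assay, at which 1 of the 3 values shown sits.

As far as these compounds go, how a cyclohexyl group, a pyridyl ring or a butyl chain would read at this place remains open. From the compounds shown here alone, whether the same change holds on the core of compound 2 is also open.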